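Swapping 4-Fluorophenyl for Thiophen-2-yl on the Shared Core

The compounds below may be only part of what the source reports. "The series", "measured", "known", "first", "only" and "open" are said of these compounds alone.

In a functional assay on A549 cells (Homo sapiens) for antiproliferative activity, read by MTT assay, with a stated time of 72 h (a higher number here means a weaker inhibitor, a lower number a stronger inhibitor), compound 1 `COc1ccc(-c2noc(CCCCCCC(=O)NO)n2)cc1` gives 13500 nM and compound 2 `O=C(CCCCCCc1nc(-c2ccc(C(F)(F)F)cc2)no1)NO` gives 14000 nM in the same test. Compound 3 `O=C(CCCCCCc1nc(-c2ccc(F)cc2)no1)NO` has the lowest number of the three at 5770 nM and so is the strongest inhibitor among them.

Compound 4 `O=C(CCCCCCc1nc(-c2cccs2)no1)NO` keeps the rest of compound 3 but carries thiophen-2-yl in place of 4-fluorophenyl on an aromatic carbon of the shared core.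

Within the data shown here, no measured step makes this exact exchange. Among the measured compounds shown here, each one swaps only a single group on an aromatic carbon. They show a 1.0-fold higher number from compound 1 to compound 2 (0.02 log units; within the scatter) and then modest moves in a 2.3-fold lower number from compound 1 to compound 3 (0.37 log units; beyond the scatter) and a 2.4-fold lower number from compound 2 to compound 3 (0.38 log units; beyond the scatter) within this small set.

Those sizes suggest a small change, and since compound 3 already has the lowest number, a slight rise seems likelier than a further fall. The expected change is a 1.4-fold higher number from compound 3 to compound 4 (0.14 log units; within the scatter) in this assay for this exchange. Compound 4 is estimated at 8000 nM with an expected range from 3500 nM to 18000 nM in this test.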

Compound 4, half-maximal inhibitory concentration: 4370 nM
Compound 4: middle estimate off by 1.8-fold (0.26 log units), on the high side, within the range that was stated.
By their numbers in this assay, from the lowest: compounds 4 and 3 (each within the scatter of the next); then compounds 1 and 2 (each within the scatter of the next).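

In this assay, the exchange gives a 1.3-fold lower number from compound 3 to compound 4 (0.12 log units; within the scatter), so the two compounds cannot be told apart in this test. Among these compounds, the earlier compounds changed only a single group on a six-membered aromatic ring of carbon only. Compound 4 shows that the place between two ring nitrogen atoms can also carry a five-membered aromatic ring with 1 hetero atom, with 5 heavy atoms instead of 7, and still read level with compound 3. Nothing available explains why these two groups read alike in this test.

Open, as far as these compounds go, is how furan-2-yl, pyridin-3-yl or an amine would read at this same place. Also open, from the compounds shown here alone, is whether a fluoro or methoxy group on the thiophen-2-yl ring would shift the number.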